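A few compounds are considered here, and "the series" means these few. Any claim that something is new, unique, unknown or untested is made for them only; others in the source may bear on it.

Compound 2, `COCCCCCCCCCCCCCCC/C=C1\CC(CO)(COC(=O)C(C)(C)C)OC1=O`, gives 1.75 ug/mL in a functional assay on SK-MEL-5 cells (Homo sapiens) for antiproliferative activity (a lower number here means a stronger inhibitor of growth, a higher number a weaker inhibitor of growth), the lowest of the two numbers obtained in that assay. Compound 1, `CC(C)(C)C(=O)OCC1(CO)C/C(=C\CCCCCCCCCCCO)C(=O)O1`, gives 5.81 ug/mL in this assay. Compound 3, `CC(C)(C)C(=O)OCC1(CO)C/C(=C/CCCCCCCCCCCCCCC=O)C(=O)O1`, reaches only a limit of this assay, > 10 ug/mL, and no number; this is the limit of > 10 ug/mL in this assay, at which 1 of the 3 values shown sits. Among the measured compounds shown here, the one measured step, a 3.3-fold lower number from compound 1 to compound 2 (0.52 log units; beyond the scatter), is modest. Compound 4, `CCCCCOCCCCCCC/C=C1\CC(CO)(COC(=O)C(C)(C)C)OC1=O`, differs from compound 2 as follows: pentyloxy in place of 8-methoxyoctyl on a saturated chain carbon, seven bonds along the chain from a double-bonded chain carbon. For the measured compounds named here, no measured step shortens the chain in this way, so none bears directly on the change; the only step seen, at the far chain end, stayed modest, and a step in this assay of no more than that size, in either direction, is expected. Compound 4 is therefore expected to give 2.8 ug/mL, between 1 ug/mL and 7.5 ug/mL, meaning an expected 1.6-fold higher number from compound 2 to compound 4 (0.20 log units; within the scatter).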

Compound 4, concentration for 50% growth inhibition: 2.99 ug/mL
Compound 4: the middle estimate sits 1.1-fold (0.03 log units) below what was measured, within the range that was stated.
By their numbers in this assay, from the lowest: compounds 2, 4 and 1 (each within the scatter of the next, the first and the last beyond it). At a limit, above all of these: compound 3.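

Pentyloxy in place of 8-methoxyoctyl, on a saturated chain carbon seven bonds along the chain from a double-bonded chain carbon, gives in this assay only a 1.7-fold higher number from compound 2 to compound 4 (0.23 log units; within the scatter), so a much shorter ether side chain is tolerated at this position. Pentyloxy in place of 4-hydroxybutyl gives a 1.9-fold lower number from compound 1 to compound 4 (0.29 log units; within the scatter), so this change cannot be told apart from the scatter either. Nothing measured here offers a reason for this tolerance.

From the compounds shown here alone, whether a terminal amine or carboxylic acid would be tolerated on this chain stays open. So does whether a plain alkyl chain without the ether oxygen would match these values.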